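Chloro to fluoro on the sulfonyl aryl: two cores compared

The source may hold more compounds than are shown below. What is called first, only, known or untested is meant among the compounds shown, and "the series" means these compounds.

Measured so far:
compound 1 `COc1ccc(Cc2nnc(NC(=O)/C(C#N)=C/c3ccccc3OS(=O)(=O)c3ccc(Cl)cc3)s2)cc1` gives 79%
compound 2 `COc1ccc(Cc2nnc(NC(=O)/C(C#N)=C/c3ccccc3OS(=O)(=O)c3ccc(F)cc3)s2)cc1` gives 80%
compound 3 `N#C/C(=C\c1ccccc1OS(=O)(=O)c1ccc(Cl)cc1)C(=O)Nc1nnc(Cc2cccc3ccccc23)s1` gives 68%

The series is read in a functional assay on RS4-11 cells (Homo sapiens) for inhibition, read by CCK-8 assay, with a stated time of 48 h, tested at 20 uM; a higher number here means more inhibition of growth at the concentration tested, a lower number less inhibition of growth. Compounds 1 and 2 share one core and differ by fluoro in place of chloro on an aromatic carbon; this gave a number 1 percentage points higher from compound 1 to compound 2 (within the scatter). Compound 3 carries a second core, differing from that of compound 1 by naphthalen-1-yl in place of 4-methoxyphenyl on a saturated chain carbon bound to an aromatic carbon, and this gave a number 11 percentage points lower from compound 1 to compound 3 (beyond the scatter).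

Compound 4 `N#C/C(=C\c1ccccc1OS(=O)(=O)c1ccc(F)cc1)C(=O)Nc1nnc(Cc2cccc3ccccc23)s1` is not yet measured. It differs from compound 3 by fluoro in place of chloro on an aromatic carbon. The change and its surroundings are the same as those between compound 1 and compound 2, only on the other core. Because the earlier step was a number 1 percentage points higher from compound 1 to compound 2 (within the scatter), the step for compound 4 is estimated at a number 1 percentage points higher from compound 3 to compound 4 (within the scatter). Whether the second core answers the change as the first did rests on that single pair, so the range is kept as wide as the usual scatter. Compound 4 is expected to give 69% in this assay, between 58% and 80%.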

Compound 4, percent growth inhibition at one concentration: 68%
For compound 4 the middle estimate is 1 percentage points above the measured one; low and high end bracket the measured number.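

In this assay, fluoro in place of chloro gives no change at the digits printed from compound 3 to compound 4 (within the scatter), and the change reads alike on both cores: the same change on two cores in this assay, a number 1 percentage points higher (within the scatter) from compound 1 to compound 2 and no change at the digits printed (within the scatter) from compound 3 to compound 4, 1 percentage points apart, within the scatter of two such steps
Naphthalen-1-yl in place of 4-methoxyphenyl gives a number 12 percentage points lower from compound 2 to compound 4 (beyond the scatter), and this change also reads alike with either halogen on the sulfonyl aryl: the same change on two cores in this assay, a number 11 percentage points lower (beyond the scatter) from compound 1 to compound 3 and a number 12 percentage points lower (beyond the scatter) from compound 2 to compound 4, 1 percentage points apart, within the scatter of two such steps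
The two changes therefore behave additively across these compounds, but the agreement for the halogen change is only between two steps within the scatter, so it shows that the change is silent on both cores and does not show that a larger step would carry over from one core to another.

Open, from the compounds shown here alone, is whether a group other than a halogen on the sulfonyl aryl, such as a methoxy group, an amine or a carboxylic acid, would move the number. Also open, going by these compounds, is how a longer chain in place of the single saturated chain carbon would read on either core.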